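The compounds below may be only part of what the source reports. "The series", "measured", "known", "first", "only" and "open" are said of these compounds alone.

Measured compounds:
compound 1 `Nc1nn(C(=O)Nc2ccc(Cc3ccccc3)cc2)c2ccccc12`, 27800 nM in a functional assay on NCI-H322M cells (Homo sapiens) for antiproliferative activity, read by sulforhodamine B assay, with a stated time of 48 h; a lower number here means a stronger inhibitor of growth, a higher number a weaker inhibitor of growth
compound 2 `Nc1nn(C(=O)Nc2ccc(Cc3ccccc3)cc2)c2ccc(Cl)cc12`, 18200 nM in this assay

Within the data shown here, compound 2 carries the lower of the two numbers in this assay, but its only neighbour is compound 1, and the step of a 1.5-fold lower number from compound 1 to compound 2 (0.18 log units; within the scatter) lies within the scatter, so the two compounds cannot be ordered on these data.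

Compound 3 `Nc1ccc2c(c1)c(N)nn2C(=O)Nc1ccc(Cc2ccccc2)cc1` is the next member. Relative to compound 2 the change is amino in place of chloro on an aromatic carbon of the shared core; the urea and benzyl portions are untouched.

Among the measured compounds shown here, the only measured step that bears on this position is the step from hydrogen to chloro at the same carbon, a 1.5-fold lower number from compound 1 to compound 2 (0.18 log units; within the scatter), which stayed within the scatter. For the measured compounds named here, a second substituent at the same place therefore gives no basis for expecting a step beyond the scatter in this assay in either direction; with only one prior step at this carbon the uncertainty is wide.

Compound 3 is estimated at 24000 nM, in a range of 8000 nM to 70000 nM, which means an expected step of a 1.3-fold higher number from compound 2 to compound 3 (0.12 log units; within the scatter).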

Compound 3, concentration for 50% growth inhibition: 13000 nM
Beside the measured number, compound 3's estimate is 1.8-fold (0.27 log units) above it; low and high end bracket the measured number.
By their numbers in this assay, from the lowest: compounds 3, 2 and 1 (each within the scatter of the next, the first and the last beyond it).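

In this assay, among these compounds, amino at this aromatic carbon gives the only step so far beyond the scatter, a 2.1-fold lower number from compound 1 to compound 3 (0.33 log units; beyond the scatter), and it is a modest one, so a substituent at this carbon can shift the growth-inhibition number measurably from that of the unsubstituted core. Amino and chloro cannot be told apart here, with a 1.4-fold lower number from compound 2 to compound 3 (0.15 log units; within the scatter), although the exchange replaces a chlorine with a nitrogen and adds a hydrogen-bond donor and acceptor to the count. The three compounds therefore form a chain in which compound 2 lies within the scatter of both compound 1 and compound 3, and only the two ends separate; no supporting data explain the separation of the ends.

From the compounds shown here alone, with only chloro and amino at this carbon, it remains open whether a hydroxy, a methoxy or an acetylamino group would fall with compound 3 or with compound 1. Also open, going by these compounds, is whether a dimethylamino group would keep the modest step seen with amino, and whether amino at another carbon of the same ring would give a similar step.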